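The source may report more compounds than this note shows. Statements on the series, on what has been measured and on what is new or still open speak of the compounds shown alone.

Working notes on a chlorinated benzoxazole/benzothiazole amide set. In an ADME assay on microsomes from liver (Mus musculus) for metabolic stability, read by LC-MS, using NADPH, with a stated time of 45 min, tested at 0.5 uM (a lower number here means slower removal, a higher number faster removal of the compound), compound 1 `CCN(CC)C(=O)CCSc1nc2cc(Cl)ccc2o1` gives 108 mL/min/g, the highest of the three numbers, although compound 3 `O=C(CCNc1nc2cc(Cl)ccc2o1)N1CCCC1` with 81.1 mL/min/g and compound 2 `O=C(CCSc1nc2cc(Cl)ccc2s1)N1CCCC1` with 67 mL/min/g both lie within the usual scatter of it, so no real ordering can be read among the three. Compound 4 `CC1CCCN1C(=O)CCSc1nc2cc(Cl)ccc2o1` is the next member and is not yet measured in this assay. It differs from compound 1 only at the amide: 2-methylpyrrolidin-1-yl in place of diethylamino on a carbonyl carbon. Within the data shown here, nothing among the measured compounds isolates this change, so the expectation is a step from compound 1 to compound 4 in this assay of a 1.3-fold lower number from compound 1 to compound 4 (0.10 log units; within the scatter), which is no further than the scatter and, if anything, slightly downward. Compound 4 is therefore estimated at 85 mL/min/g, expected to fall between 45 mL/min/g and 160 mL/min/g.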

Compound 4, intrinsic clearance in a liver preparation (reported as CLH), per the amount of preparation that the assay uses: 98 mL/min/g
Beside the measured number, compound 4's estimate is 1.2-fold (0.06 log units) below it, and the stated range covers the measured number.
By their numbers in this assay, from the lowest: compounds 2, 3, 4 and 1 (each within the scatter of the next).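

Among these compounds, this is the first reading that isolates the amide position: in this assay, 2-methylpyrrolidin-1-yl in place of diethylamino on a carbonyl carbon gives a 1.1-fold lower number from compound 1 to compound 4 (0.04 log units; within the scatter), so on this core, the swap to a ring-bearing amide does not separate the two compounds. No measurement bears on why this is so.

On these data alone, whether a morpholine amide or a carboxylic acid at the same carbonyl carbon would give a step beyond the scatter remains open. As far as these compounds go, the effect of a longer chain on the shared core is also open.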